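This account rests on a few compounds, and the source may have more. Where it says the series, first, only, none or still open, it means among the compounds named here.

Compound 1 `O=C(NO)c1ccc(NCc2nc(-c3ccccc3)nn2-c2ccccc2Cl)cc1`: 9630 nM
Compound 2 `Cc1ccc(-c2nc(CNc3ccc(C(=O)NO)cc3)n(-c3ccccc3)n2)cc1`: > 20000 nM
Compound 3 `O=C(NO)c1ccc(NCc2nc(-c3ccccc3)nn2-c2ccc(F)cc2)cc1`: 10500 nM

In a functional assay on MGC-803 cells (Homo sapiens) for antiproliferative activity, read by MTT assay, with a stated time of 72 h (a higher number here means a weaker inhibitor, a lower number a stronger inhibitor), compound 1 gives 9630 nM and compound 3 gives 10500 nM, so both are weak inhibitors of cell growth. Among the compounds with values here, the only measured step, a 1.1-fold higher number from compound 1 to compound 3 (0.04 log units; within the scatter), alters the group on the aromatic nitrogen and leaves the result unchanged within the scatter. For compound 2 this assay reports no number, only a limit of > 20000 nM. Compound 2 thus sits at the limit of > 20000 nM in this assay, at which 1 of the 3 values shown sits, and all that is known of it is that it is at least as weak as the other two.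

Compound 4 `Cc1ccsc1-c1nc(CNc2ccc(C(=O)NO)cc2)n(-c2ccccc2)n1` differs from compound 2 by 3-methylthiophen-2-yl in place of 4-methylphenyl on an aromatic carbon. Within the data shown here, no measured step touches this place, since the one measured step concerns the aromatic nitrogen instead, so it gives no direct guide. What the numbers do show is that compound 1 and compound 3, with a phenyl group at that place, reach only weak inhibition, and compound 2, with 4-methylphenyl there, falls at the limit. Compound 4 is therefore expected to remain a weak inhibitor, with an estimated value of 20000 nM and a range from 8000 nM to 50000 nM. Measured against compound 2, this estimate would mean an expected step of a number no higher from compound 2 to compound 4 (the limit leaves the size open), though a limit rather than a number is a real possibility.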

Compound 4, half-maximal inhibitory concentration: 8890 nM
The estimate for compound 4 lay 2.2-fold (0.35 log units) above the measured number, and the stated range covers the measured number.
By their numbers in this assay, from the lowest: compounds 4, 1 and 3 (each within the scatter of the next). At a limit, above all of these: compound 2.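

In this assay, within the data shown here, the group on the aromatic carbon of the five-membered ring, a place no earlier step touched, turns out to affect the result: the change from 4-methylphenyl to 3-methylthiophen-2-yl gives an at least 2.2-fold lower number from compound 2 to compound 4 (0.35 log units; beyond the scatter), the first step here to lie beyond the scatter. The exchange replaces a six-membered aromatic ring of carbon only with a five-membered aromatic ring holding one hetero atom, and it adds one counted hydrogen-bond acceptor, so several features differ at once and this single pair cannot separate them. The true size of the step remains unknown because compound 2 has a limit and not a number: the limit of > 20000 nM in this assay, at which 1 of the 4 values shown sits.

The compounds shown leave open which of these features matters, and whether the same exchange would have a similar effect with a different group on the aromatic nitrogen. They also leave open how the number would respond if an amine or a carboxylic acid stood at this place instead of an aromatic ring.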